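Removing fluorines, adding a methyl branch: compound 3 expected

A few compounds are considered here, and "the series" means these few. Any claim that something is new, unique, unknown or untested is made for them only; others in the source may bear on it.

Compound 1, `FC1(Cc2ccccc2)CCN(CCCc2c[nH]c3ccc(-n4cnnc4)cc23)CC1`, in a functional assay on CHO cells for agonist activity at 5-hydroxytryptamine receptor 1D (Homo sapiens), read by GTPgammaS binding (a higher number here means that more compound is needed for the effect, a lower number that less compound is needed), compound 1 gives 0.4 nM.
Compound 2, `FC1(Cc2ccccc2C(F)(F)F)CCN(CCCc2c[nH]c3ccc(-n4cnnc4)cc23)CC1`, in this assay compound 2 gives 0.2 nM.
Compound 3, `CC(CC1(F)CCN(CCCc2c[nH]c3ccc(-n4cnnc4)cc23)CC1)c1ccccc1`, awaits this assay.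

Compound 2 holds the lowest of the two measured numbers, though its nearest neighbour compound 1 lies within the scatter: a 2.0-fold lower number from compound 1 to compound 2 (0.30 log units; within the scatter). Compound 3 differs from compound 2 by 1-phenylethyl in place of 2-(trifluoromethyl)phenyl on a saturated chain carbon bound to a saturated ring carbon. For the measured compounds named here, the only measured step touches the same benzyl group, and it stayed within the scatter, so the shared core seems to tolerate changes there. Compound 3 is therefore expected to show no step beyond the scatter, a 2.0-fold higher number from compound 2 to compound 3 (0.30 log units; within the scatter), with an estimate of 0.4 nM, ranging from 0.1 nM to 1.6 nM.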

Compound 3, half-maximal effective concentration: 2.6 nM
Compound 3: the middle estimate sits 6.5-fold (0.81 log units) below what was measured; measured number above the stated range.
By their numbers in this assay, from the lowest: compounds 2 and 1 (each within the scatter of the next); then compound 3.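

For the compounds shown here, the change to 1-phenylethyl on a saturated chain carbon bound to a saturated ring carbon gives a 13-fold higher number from compound 2 to compound 3 (1.11 log units; beyond the scatter) and a 6.5-fold higher number from compound 1 to compound 3 (0.81 log units; beyond the scatter) in this assay and these are the first steps here beyond the scatter. This position therefore does not tolerate every change, although the earlier step on the aromatic ring stayed within the scatter. Nothing available explains the higher number of compound 3.

The compounds shown leave open whether a hydroxyl group in place of the methyl branch would give a similar number. They also leave open whether trifluoromethyl on the aromatic ring of compound 3 would alter it.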